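Swapping the pyridine head group for a pyrazole

The source may hold more compounds than are shown below. What is called first, only, known or untested is meant among the compounds shown, and "the series" means these compounds.

Of the compounds shown here, three sharing one core have been tested in a functional assay on A549 cells (Homo sapiens) for antiproliferative activity, read by sulforhodamine B assay, with a stated time of 72 h; a lower number here means a stronger inhibitor, a higher number a weaker inhibitor. Compound 1 `COc1ncc(-c2ccc3ncnc(Nc4ccc(OCCO)c(F)c4)c3c2)cc1NS(=O)(=O)c1ccc(F)cc1F` gives 6640 nM. Compound 2 `COc1ncc(-c2ccc3ncnc(Nc4cnn(CCCO)c4)c3c2)cc1NS(C)(=O)=O` gives 3600 nM. Compound 3 `COc1ncc(-c2ccc3ncnc(Nc4ccc(OCCCO)nc4)c3c2)cc1NS(=O)(=O)c1ccc(F)cc1F` gives 9360 nM, the highest number of the three; compound 1 sits within the scatter of it, while compound 2 lies beyond the scatter below it. Compound 4 `COc1ncc(-c2ccc3ncnc(Nc4cnn(CCCO)c4)c3c2)cc1NS(=O)(=O)c1ccc(F)cc1F` has not yet been measured; it differs from compound 3 in one place: 1-(3-hydroxypropyl)-1H-pyrazol-4-yl in place of 6-(3-hydroxypropoxy)pyridin-3-yl on a nitrogen on an aromatic ring. For the measured compounds named here, only one measured step changes the same head group: the step of a 1.4-fold higher number from compound 1 to compound 3 (0.15 log units; within the scatter), which did not move the number beyond the scatter. Compound 2 carries the same pyrazolyl head group as compound 4 but a different sulfonamide, so it offers only a hint, not a step. Taken together, the expected step in this assay a 2.1-fold lower number from compound 3 to compound 4 (0.32 log units; beyond the scatter) is a modest shift toward a lower number, possibly within the scatter. For compound 4 the estimate in this assay is 4500 nM, with a range from 2000 nM to 10000 nM.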

Compound 4, half-maximal inhibitory concentration: 4830 nM
Beside the measured number, compound 4's estimate is 1.1-fold (0.03 log units) below it; the measured number falls inside the stated range.
By their numbers in this assay, from the lowest: compounds 2, 4, 1 and 3 (each within the scatter of the next, the first and the last beyond it).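

In this assay, replacing either earlier head group with the 1-(3-hydroxypropyl)-1H-pyrazol-4-yl group stays within the usual scatter (a 1.9-fold lower number from compound 3 to compound 4 (0.29 log units; within the scatter)) and (a 1.4-fold lower number from compound 1 to compound 4 (0.14 log units; within the scatter)). For the compounds shown here, the new compound also gives the first pair that differs only at the sulfonyl sulfur, and 2,4-difluorophenyl in place of methyl there stays within the scatter too (a 1.3-fold higher number from compound 2 to compound 4 (0.13 log units; within the scatter)). This assay therefore does not separate these groups in compounds 1, 2, 3 and 4, and nothing available accounts for these numbers.

As far as these compounds go, whether the group on the aromatic nitrogen matters more when its hydroxyl is replaced by an amine or a carboxylic acid remains open. A longer chain on the pyrazole is equally untested in the compounds shown.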